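Removing the tosyl group from compound 1

The compounds below may be only part of what the source reports. "The series", "measured", "known", "first", "only" and "open" are said of these compounds alone.

Measured compounds:
compound 1 `Cc1ccc(S(=O)(=O)n2c(-c3ccccc3)c(C#CCO[C@H]3CC[C@H](N)[C@H](C)O3)c3ccccc32)cc1` with 43.2%
compound 2 `Cc1ccc(S(=O)(=O)n2c(-c3ccccc3)c(C#CCO[C@H]3C[C@H](N)[C@@H](O)[C@H](C)O3)c3ccccc32)cc1` with 92.8%

Going by the values given here, in an assay on isolated protein for inhibition of DNA topoisomerase 1 (Homo sapiens), with a stated time of 30 min, tested at 100 uM (a lower number here means less inhibition, a higher number more inhibition at the concentration tested (going by the name of the read-out)), compound 1 gives the lowest of the two numbers; the only other compound, compound 2, lies a number 49.6 percentage points higher from compound 1 to compound 2 (beyond the scatter). Compound 3 `C[C@@H]1O[C@@H](OCC#Cc2c(-c3ccccc3)[nH]c3ccccc23)CC[C@@H]1N` differs from compound 1 by hydrogen in place of (4-methylphenyl)sulfonyl on an aromatic nitrogen. Among the compounds with values here, the one measured step concerns a different part of the molecule, the ring attached through the oxygen on a saturated carbon, so no measured step bears on this change. Without guidance, the expected step is a number 3.2 percentage points lower from compound 1 to compound 3 (within the scatter), within the scatter, and compound 3 is estimated at 40%, between 12% and 68%.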

Compound 3, a percentage reported as inhibition, at one concentration (the size of the read-out at that concentration, not a potency): 4%
Compound 3: the middle estimate sits 36 percentage points above what was measured, and the stated range ends above it.
By their numbers in this assay, from the lowest: compound 3; then compound 1; then compound 2.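

In this assay, replacing the (4-methylphenyl)sulfonyl group on the aromatic nitrogen with hydrogen gives a number 39.2 percentage points lower from compound 1 to compound 3 (beyond the scatter) and so shows that the group on this nitrogen, and not only the ring attached through the oxygen, bears on the inhibition seen. The change is large, and the aromatic nitrogen is clearly a position where the substituent counts. Nothing measured here gives a reason for this drop. Going by these compounds, it remains open whether a methyl or an acetyl group on this nitrogen would keep part of the inhibition, and whether the ring of compound 2 would hold its number with hydrogen on the nitrogen.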